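The compounds below may be only part of what the source reports. "The series", "measured", "known", "first", "only" and "open" are said of these compounds alone.

Measured so far in an ADME assay on BJ cells (Homo sapiens) for cytotoxicity, with a stated time of 72 h; on this read-out higher numbers stand for an effect only at larger amounts of compound and lower numbers for an effect already at smaller amounts
compound 1 `Cc1cc(NC(=O)Nc2cccc(F)c2)c2ccccc2n1` gives > 25000 nM
compound 2 `Cc1cc(NC(=O)Nc2cc(F)cc(F)c2)c2ccccc2n1` gives > 25000 nM

Compound 1 gives > 25000 nM in this assay as a limit of the assay and not as a number. Compound 2 gives > 25000 nM as a limit too. The next compound to follow is compound 3 `Cc1cc(NC(=O)Nc2cccc(OC(F)(F)F)c2)c2ccccc2n1`, which carries trifluoromethoxy in place of fluoro on an aromatic carbon, meta to a large group trifluoromethoxy in place of fluoro on an aromatic carbon and has not yet been measured. Within the data shown here, the one measured step that bears on this change is a step that the two limits leave unreadable from compound 1 to compound 2 and it offers no size to carry over. The series therefore rests on the limit of > 25000 nM in this assay, at which 2 of the 2 values shown sit, and gives no direction for the change. No step beyond the scatter is expected, and another limit reading for compound 3 is the likeliest outcome. The expected step is a number no higher from compound 1 to compound 3 (the limit leaves the size open) and it remains only an estimate. For compound 3 the estimated value is 25000 nM with an expected range from 10000 nM to 40000 nM.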

Compound 3, half-maximal effective concentration: 25000 nM
Beside the measured number, compound 3's estimate shows no gap at the digits printed; the range from low to high includes it.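

In this assay, among these compounds, trifluoromethoxy in place of fluoro on this aromatic carbon, meta to a large group, gives the only value shown that is a number and not a limit. The change reads as a number no higher from compound 1 to compound 3 (the limit leaves the size open), so neither this step nor the earlier step between the two limits has a readable size. Even with the larger group, the series stays at the edge of what this assay can read: the limit of > 25000 nM in this assay, at which 2 of the 3 values shown sit.

It remains open whether any group at this place would bring the effect down to clearly smaller amounts of compound, as the shown fluoro and trifluoromethoxy compounds give no measured size for such a change. An amine, a carboxylic acid or a longer alkyl chain in place of trifluoromethoxy would show whether the read-out moves away from this limit, and changes to the shared core remain untested in the compounds shown.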